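This account rests on a few compounds, and the source may have more. Where it says the series, first, only, none or still open, it means among the compounds named here.

Three compounds in the series carry a number in a functional assay on the whole organism (Abdomen, strain Swiss) for inhibition, with Mus musculus as the target, with a stated time of 1 h, at a dose of 100 umol/kg by the oral route; on this read-out lower numbers stand for less inhibition and higher numbers for more inhibition at the one dose given (going by the name of the read-out). Compound 1 `c1ccc(Nc2c(-c3ccccc3)nc3ccccn23)cc1` gives 10.8% in this assay. Compound 3 `CS(=O)(=O)c1ccc(Nc2c(-c3ccncc3)nc3ccccn23)cc1` gives 33.6% in this assay. Compound 2 `CS(=O)(=O)c1ccc(-c2nc3ccccn3c2Nc2ccccn2)cc1` gives 22.2% in this assay and stands second highest of the three numbers; its nearest neighbour is compound 1, lower by a margin beyond the scatter, and its furthest is compound 3, higher by a margin beyond the scatter. No pair among these three differs in only one place, so no single step is counted between measured compounds.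

Compound 4 `CS(=O)(=O)c1ccc(-c2nc3ccccn3c2Nc2ccccc2)cc1` is the next compound to go into this assay. It differs from compound 2 in one place: phenyl in place of pyridin-2-yl on a nitrogen on an aromatic ring. For the measured compounds named here, nothing among the measured compounds isolates this change, so the expected size of the step rests on the spread of the three numbers alone. No step beyond the scatter is expected in either direction from the value of compound 2. The expected outcome for compound 4 is 19%, with a range of 6% to 34%, which means an expected step of a number 3.2 percentage points lower from compound 2 to compound 4 (within the scatter).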

Compound 4, a percentage reported as inhibition, in the whole organism at one dose (the size of the read-out at that dose, not a potency): 7.4%
Compound 4: the middle estimate sits 11.6 percentage points above what was measured; the range from low to high includes it.
By their numbers in this assay, from the lowest: compounds 4 and 1 (each within the scatter of the next); then compound 2; then compound 3.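

Phenyl in place of pyridin-2-yl on a nitrogen on an aromatic ring gives a number 14.8 percentage points lower from compound 2 to compound 4 (beyond the scatter) in this assay at the one dose given, the first single change in the series that can be read, and it shows that the two rings are not interchangeable at this position. Methylsulfonyl in place of hydrogen on an aromatic carbon gives a number 3.4 percentage points lower from compound 1 to compound 4 (within the scatter) and so, with anilino held constant, adds no step beyond the scatter. Nothing on hand accounts for either step.

Whether the pyridin-2-yl step persists without methylsulfonyl remains open, as the shown compounds offer no such pair. Also open, going by these compounds, is how pyridin-3-yl, pyridin-4-yl or a cyclohexyl would read on the same nitrogen, and a single dose gives no potency for any of them.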